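From pyridin-4-yl to pyridin-3-yl at the assay limit

A few compounds are considered here, and "the series" means these few. Any claim that something is new, unique, unknown or untested is made for them only; others in the source may bear on it.

Measured in a functional assay on DU-145 cells (Homo sapiens) for antiproliferative activity, read by MTT assay, with a stated time of 24 h; on this read-out lower numbers stand for stronger inhibition and higher numbers for weaker inhibition:
Compound 1 `COc1ccc(-c2noc(-c3ccncc3)n2)cc1OC1CCCC1`: > 1000000 nM
Compound 2 `Fc1ccc(-c2nc(-c3ccccc3)no2)cc1`: > 1000000 nM

Both entries are limits of the assay and not numbers. Compound 1 stands at the limit of > 1000000 nM in this assay, at which 2 of the 2 values shown sit, so no number places it relative to compound 2.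

Compound 3 `COc1ccc(-c2noc(-c3cccnc3)n2)cc1OC1CCCC1` has the same atoms as compound 1, joined differently: pyridin-3-yl in place of pyridin-4-yl on an aromatic carbon. In words, pyridin-3-yl stands in place of pyridin-4-yl on an aromatic carbon of a five-membered aromatic ring with 2 nitrogen and 1 oxygen.

Among the compounds with values here, no two measured compounds differ in one place, so nothing sizes this change directly in this assay. The expectation rests on compound 1, whose result of > 1000000 nM is a limit. No shift beyond the usual scatter is expected in either direction, and the assay may again report only a limit. The estimated change is a number no higher from compound 1 to compound 3 (the limit leaves the size open). For compound 3 the expected value is 1000000 nM, with an estimated range of 100000 nM to 2000000 nM.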

Compound 3, half-maximal inhibitory concentration: > 1000000 nM
Compound 3 was reported as a limit; the forecaster's own chance of this, stated with the estimate: 70%; the middle value sits exactly at the limit.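

Compound 3 gives > 1000000 nM in this assay, which is a limit of the assay and not a number. Within the data shown here, compound 1 also stands at a limit, and no step from compound 1 to compound 3 can be read. Whether pyridin-3-yl and pyridin-4-yl differ at all in this assay stays open, as every compound shown stands at the same limit: the limit of > 1000000 nM in this assay, at which 3 of the 3 values shown sit.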